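The source may hold more compounds than are shown below. What is called first, only, known or untested is meant among the compounds shown, and "the series" means these compounds.

Measured so far:
Compound 1, `O=c1[nH]cnn2c([C@@H]3O[C@H](CO)C[C@H]3O)ccc12`: in an ADME assay on cells (Macrophage, Mus musculus) for cytotoxicity (a higher number here means that more compound is tolerated, a lower number that less compound is tolerated), compound 1 gives > 64000 nM, which is a limit of the assay rather than a number.
Compound 2, `O=c1[nH]cnn2c([C@@H]3O[C@H](CO)[C@@H](O)[C@H]3O)cc(Br)c12`: in this assay compound 2 gives > 64000 nM, again a limit of the assay and not a number.

Compound 2 therefore stands at the tolerated end of what this assay can report, and compound 1 shows the same kind of limit, so neither value separates the two (the limit of > 64000 nM in this assay, at which 2 of the 2 values shown sit). Within the data shown here, no step between two measured compounds has been recorded, so the size of any change can only be expected, not read off. The unmeasured compound 3, `O=c1[nH]cnn2c([C@@H]3O[C@H](CO)[C@@H](O)[C@H]3O)ccc12`, differs from compound 2 in one place: hydrogen in place of bromo on an aromatic carbon. With both measured compounds sitting at the limit, the step from compound 2 to compound 3 is expected to be none beyond the scatter in this assay, that is a step that the limit leaves unreadable from compound 2 to compound 3. Compound 3 is accordingly estimated at 80000 nM, with a range from 40000 nM to 200000 nM, most likely reported again only as a limit.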

Compound 3, half-maximal cytotoxic concentration: > 64000 nM
Compound 3: no number, only a limit; the forecaster's own chance of this, stated with the estimate: 85%; the middle value is on the limit's open side.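

In this assay compound 3 gives > 64000 nM as well, a limit and not a number. Among these compounds, no step from compound 1 or compound 2 to compound 3 can be read. Still open is at what concentration any of the three compounds harms these cells, and whether the bromo or the hydroxy makes a difference there: the limit of > 64000 nM in this assay, at which 3 of the 3 values shown sit.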